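Adding a Second Trifluoromethyl to a Benzamide Core

The compounds below may be only part of what the source reports. "The series", "measured", "known", "first", "only" and "open" are said of these compounds alone.

Of the compounds shown here, two sharing one core have been measured so far. Compound 1 `O=C(Nc1nc2ccccc2[nH]1)c1ccccc1C(F)(F)F` and compound 2 `O=C(Nc1nc2ccccc2[nH]1)c1cccc(C(F)(F)F)c1` each carry a single trifluoromethyl on the benzamide ring, in different places. In an assay on BV-2 cells for positive allosteric modulation of metabotropic glutamate receptor 5 (Mus musculus), read by Griess assay, with stated times of 1 h and 24 h (on this read-out higher numbers stand for weaker inhibition and lower numbers for stronger inhibition), compound 1 gives 88000 nM, while compound 2 gives 12000 nM. Compound 2 therefore stands at the lowest of the two numbers, and the gap to compound 1 lies beyond the usual scatter.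

Compound 3 `O=C(Nc1nc2ccccc2[nH]1)c1cc(C(F)(F)F)ccc1C(F)(F)F` has not yet been tested in this assay. Compared with compound 2, the change is trifluoromethyl in place of hydrogen on an aromatic carbon, so compound 3 keeps the trifluoromethyl of compound 2 and gains a second one.

Among the compounds with values here, no directly measured step covers this change. Within the data shown here, the only guidance is that the single trifluoromethyl of compound 1 gives a weaker result than that of compound 2, so the combination in compound 3 is expected to move toward weaker inhibition rather than stronger, with a step of a 3.3-fold higher number from compound 2 to compound 3 (0.52 log units; beyond the scatter) expected because compound 1 gives 88000 nM. Compound 3 is thus estimated at 40000 nM, within a range from 10000 nM to 150000 nM.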

Compound 3, half-maximal inhibitory concentration: 34000 nM
Estimate against measurement, compound 3: 1.2-fold (0.07 log units) above; the range from low to high includes it.
By their numbers in this assay, from the lowest: compound 2; then compound 3; then compound 1.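

In this assay, a trifluoromethyl in place of hydrogen on the aromatic carbon ortho to a large group and para to a trifluoromethyl group gives a 2.8-fold higher number from compound 2 to compound 3 (0.45 log units; beyond the scatter) and so weakens inhibition when compound 2 is the starting point. The same kind of change read from the other side gives a 2.6-fold lower number from compound 1 to compound 3 (0.41 log units; beyond the scatter) and so strengthens inhibition, which shows that adding a trifluoromethyl has no single direction across these three compounds: its outcome depends on the compound that receives it. Nothing measured alongside these numbers speaks to what lies behind the two opposite steps.

The compounds shown carry only hydrogen or trifluoromethyl on the benzamide ring, so it remains open whether a chlorine, a methoxy group or an amine on this same carbon would shift the number from compound 2 as far, or in the same direction. From the compounds shown here alone, it also remains open whether the opposite directions seen here would persist with a different second group, since a single set of three compounds offers just one such comparison.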